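The compounds below may be only part of what the source reports. "The series", "measured", "known", "first", "only" and "open" are said of these compounds alone.

Measured compounds:
Compound 1 `CNC(=O)CCCCCCCn1nc(-c2ccc3oc(N)nc3c2)c2c(N)ncnc21` gives 2770 nM in a functional assay on Huh-7 cells (Homo sapiens) for inhibition, read by MTT assay, with a stated time of 72 h; a higher number here means a weaker inhibitor, a lower number a stronger inhibitor.
Compound 2 `Nc1ncnc2c1c(-c1cnc3[nH]ccc3c1)nn2CCCCCCC(=O)NO` gives 50900 nM in this assay.
Compound 3 `Nc1ncnc2c1c(-c1cnc3[nH]ccc3c1)nn2CCCCCCCCCC(=O)NO` gives 10100 nM in this assay.

Compound 1 stands lowest of the three numbers, with compound 3 nearest and compound 2 furthest from it. Compound 4 `Nc1nc2cc(-c3nn(CCCCC(=O)NO)c4ncnc(N)c34)ccc2o1` has not yet been measured; it differs from compound 1 by hydroxycarbamoyl in place of 3-(methylcarbamoyl)propyl on a saturated chain carbon, four bonds along the chain from an aromatic nitrogen. For the measured compounds named here, the one measured step that bears on this is a 5.0-fold lower number from compound 2 to compound 3 (0.70 log units; beyond the scatter), where the chain carrying the hydroxycarbamoyl grew longer and the number fell. Compound 4 moves the other way, to a shorter chain ending in hydroxycarbamoyl, so a higher number than for compound 1 is expected, a 5.4-fold higher number from compound 1 to compound 4 (0.73 log units; beyond the scatter). Compound 4 is estimated at 15000 nM, with a range from 4000 nM to 60000 nM.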

Compound 4, half-maximal inhibitory concentration: 9220 nM
Compound 4: middle estimate off by 1.6-fold (0.21 log units), on the high side; the range from low to high includes it.
By their numbers in this assay, from the lowest: compound 1; then compounds 4 and 3 (each within the scatter of the next); then compound 2.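

In this assay the change on this saturated chain carbon gives a 3.3-fold higher number from compound 1 to compound 4 (0.52 log units; beyond the scatter) on the shared core, so on this core the shorter chain ending in hydroxycarbamoyl does not bring the number down. This single step alters chain length and end group together, and it cannot separate the two. Nothing measured here accounts for the rise. Still open, as far as these compounds go, is how a longer chain ending in hydroxycarbamoyl, or a chain of the same length ending in a carboxylic acid, would read on this core.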